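Series notes: the step from compound 2 to compound 4

The compounds below may be only part of what the source reports. "The series", "measured", "known", "first", "only" and "open" are said of these compounds alone.

Measured so far:
- Compound 1 `O=S(=O)(Nc1ccc(-c2nc3ccccc3o2)cc1)c1ccc(Cl)c(C(F)(F)F)c1` gives > 63000 nM in an assay on isolated protein for inhibition of malate dehydrogenase, mitochondrial (Sus scrofa), with stated times of 45 min and 30 min; a lower number here means a stronger inhibitor, a higher number a weaker inhibitor; this is a limit of the assay, not a number.
- Compound 2 `Cc1ccc(S(=O)(=O)Nc2ccc3oc(-c4ccccc4)nc3c2)cc1` gives > 63000 nM in this assay; this is a limit, not a number.
- Compound 3 `O=S(=O)(Nc1ccc(-c2nc3ccccc3o2)cc1)c1ccc(F)c(C(F)(F)F)c1` gives > 63000 nM in this assay; this is a limit, not a number.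

Within the data shown here, every value obtained so far sits at the limit of > 63000 nM in this assay, at which 3 of the 3 values shown sit, so no compound in the set has a measured number. Among the measured compounds shown here, the one single-point change among measured compounds, a step that the two limits leave unreadable from compound 1 to compound 3, runs between two limits and its size cannot be read. Compound 2 therefore stands at a limit only, with no numerical position within the series.

Compound 4 `COc1cccc(S(=O)(=O)Nc2ccc3oc(-c4ccccc4)nc3c2)c1` differs from compound 2 in one place: 3-methoxyphenyl in place of 4-methylphenyl on a sulfonyl sulfur. For the measured compounds named here, no measured step touches this position, and the only step available is unreadable, so nothing in the data sets a direction or size for the change in this assay. The working expectation is that compound 4 remains at the limit as well; the estimate for compound 4 is 100000 nM, with a range from 30000 nM to 300000 nM. The step that the limit leaves unreadable from compound 2 to compound 4 is thus expected to show nothing readable beyond the scatter.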

Compound 4, half-maximal inhibitory concentration: > 63000 nM
Compound 4: only a limit was reported; the forecaster's own chance of this, stated with the estimate: 85%; the middle value lies beyond the limit too.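

Compound 4, like compound 2, stands only at a limit of the assay, so the step between these two compounds cannot be read. The compounds shown leave open whether any change to this series gives a measured number in this assay, since all values share one ceiling: the limit of > 63000 nM in this assay, at which 4 of the 4 values shown sit.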